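The source may report more compounds than this note shows. Statements on the series, on what has been measured and on what is new or still open speak of the compounds shown alone.

Compound 2 `O=C(NCCCCc1ccccc1)n1c(=O)oc2ccc([N+](=O)[O-])cc21`: 3 nM
Compound 1 `O=C(NCCCCc1ccccc1)n1c(=O)oc2ccc(Cl)cc21`: 15 nM

In an assay on HEK293 cells for inhibition of acid ceramidase (Homo sapiens), with a stated time of 10 min (on this read-out higher numbers stand for weaker inhibition and lower numbers for stronger inhibition), compound 2 gives the lowest of the two numbers; its nearest neighbour is compound 1, separated by a 5.0-fold lower number from compound 1 to compound 2 (0.70 log units; beyond the scatter). Compound 3 `O=C(NCCCCc1ccccc1)n1c(=O)oc2ccc(Br)cc21` has not been measured; it differs from compound 2 by bromo in place of nitro on an aromatic carbon. Within the data shown here, only one measured step bears on this change: because a 5.0-fold lower number from compound 1 to compound 2 (0.70 log units; beyond the scatter) came with putting nitro in place of chloro, taking the nitro away again is expected to send the number back up, giving for compound 3 a 4.0-fold higher number from compound 2 to compound 3 (0.60 log units; beyond the scatter). Compound 3 is therefore estimated at 12 nM, within 5 nM to 30 nM.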

Compound 3, half-maximal inhibitory concentration: 22 nM
Compound 3: middle estimate off by 1.8-fold (0.26 log units), on the low side; low and high end bracket the measured number.
By their numbers in this assay, from the lowest: compound 2; then compounds 1 and 3 (each within the scatter of the next).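

In this assay, bromo in place of nitro gives a clear rise (a 7.3-fold higher number from compound 2 to compound 3 (0.87 log units; beyond the scatter)), so nitro stands apart from bromo at this position. Bromo in place of chloro leaves the two halogen compounds indistinguishable (a 1.5-fold higher number from compound 1 to compound 3 (0.17 log units; within the scatter)). Among these three groups, the lower number therefore belongs to nitro alone, and the halogens behave alike.

Nothing available explains why nitro differs from the two halogens. Going by these compounds, whether a nitrile, a methoxy group or an amine at this position would match nitro or the halogens remains open.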